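Ethyl to methylsulfanyl on the benzimidazole-free shared core

The source may hold more compounds than are shown below. What is called first, only, known or untested is meant among the compounds shown, and "the series" means these compounds.

Measured so far:
compound 1 `CCc1nc2cccc(C(=O)O)c2n1Cc1ccc(-c2ccccc2-c2noc(O)n2)cc1` — 88%
compound 2 `CCCOc1nc2cccc(C(=O)O)c2n1Cc1ccc(-c2ccccc2-c2noc(O)n2)cc1` — 100%

In a functional assay on the whole organism for inhibition, with Rattus norvegicus as the target, with a stated time of 3 h, at a dose of 1 mg/kg by the oral route (a lower number here means less inhibition, a higher number more inhibition at the dose given (going by the name of the read-out)), compound 1 stands lowest of the two numbers; compound 2 lies a number 12 percentage points higher from compound 1 to compound 2 (beyond the scatter) above it, a modest step. Compound 3 `CSc1nc2cccc(C(=O)O)c2n1Cc1ccc(-c2ccccc2-c2noc(O)n2)cc1` is unmeasured and differs from compound 1 by methylsulfanyl in place of ethyl on an aromatic carbon, on the same aromatic carbon that the propoxy step touched. That step is the only one that bears, and it was modest; with no measured exchange of ethyl for a sulfur-linked group, the change is expected to stay within the scatter. Compound 3 is therefore estimated at 90% (range 76% to 100%), a step of a number 2 percentage points higher from compound 1 to compound 3 (within the scatter).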

Compound 3, a percentage reported as inhibition, in the whole organism at one dose (the size of the read-out at that dose, not a potency): 100%
Beside the measured number, compound 3's estimate is 10 percentage points below it; low and high end bracket the measured number.
By their numbers in this assay, from the lowest: compound 1; then compounds 2 and 3 (each within the scatter of the next).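

In this assay, methylsulfanyl on this aromatic carbon between two ring nitrogen atoms gives a number 12 percentage points higher from compound 1 to compound 3 (beyond the scatter) in place of ethyl, so a sulfur-linked group matches the gain seen with propoxy. Exchanging propoxy for methylsulfanyl gives no change at the digits printed from compound 2 to compound 3 (within the scatter) and does not separate the two groups, leaving ethyl as the only one apart among the three. No available evidence bears on the reason for this result.

As far as these compounds go, how an amine or a longer alkyl chain on this carbon would compare remains open. From the compounds shown here alone, whether methylsulfanyl and propoxy would separate at a lower dose also remains open.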